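The compounds below may be only part of what the source reports. "The series", "measured", "known", "first", "only" and "open" are said of these compounds alone.

Measured compounds in an assay on membranes from lung (Cavia porcellus) for binding affinity to cysteinyl leukotriene receptor (Homo sapiens); on this read-out lower numbers stand for stronger inhibition and higher numbers for weaker inhibition:
compound 1 `CC(CCCC(=O)O)c1cccc(OCc2ccc3ccccc3n2)c1` gives 90 nM
compound 2 `O=C(O)CCC(Cc1cccc(OCc2ccc3ccccc3n2)c1)c1ccccc1` gives 52 nM
compound 3 `CC(CCCc1nnn[nH]1)c1cccc(OCc2ccc3ccccc3n2)c1` gives 31 nM

Compound 1 and compound 3 share one core and differ in a single place: 1H-tetrazol-5-yl in place of carboxy on a saturated chain carbon, four bonds along the chain from an aromatic carbon. Within the data shown here, this change gives a 2.9-fold lower number from compound 1 to compound 3 (0.46 log units; beyond the scatter), the only step in the set that reaches beyond the usual scatter. Compound 2 carries a different core; how the core of compound 2 differs from the core of compound 1 is not broken down here. In this assay compound 2 and compound 1 give values that lie within the usual scatter of each other, and the same holds for compound 2 against compound 3, so no order among these pairs is read from the data.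

Compound 4 `c1ccc(C(CCc2nnn[nH]2)Cc2cccc(OCc3ccc4ccccc4n3)c2)cc1` has not yet been measured in this assay. It differs from compound 2 in one place: 1H-tetrazol-5-yl in place of carboxy on a saturated chain carbon, three bonds along the chain from an aromatic carbon. Among the measured compounds shown here, this is the same kind of change as the one from compound 1 to compound 3, but not the same change: there the place is four bonds along the chain from an aromatic carbon, here it is three bonds along the chain from an aromatic carbon. For the measured compounds named here, a step of comparable size is expected from compound 2 to compound 4, namely a 2.6-fold lower number from compound 2 to compound 4 (0.41 log units; beyond the scatter), because a 2.9-fold lower number from compound 1 to compound 3 (0.46 log units; beyond the scatter) is the single precedent for this kind of change in the set, and the shift of the place by one bond leaves the expectation less certain. For compound 4 in this assay the estimate is 20 nM, expected to fall between 8 nM and 50 nM.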

Compound 4, inhibition constant: 14 nM
Estimate against measurement, compound 4: 1.4-fold (0.15 log units) above; the measured number falls inside the stated range.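

In this assay, putting 1H-tetrazol-5-yl in place of carboxy on the core of compound 2 gives a 3.7-fold lower number from compound 2 to compound 4 (0.57 log units; beyond the scatter). Set beside the earlier step on the core of compound 1, the change carries over in the same direction and with no difference in size that can be read: the same change on two cores in this assay, a 2.9-fold lower number (0.46 log units; beyond the scatter) from compound 1 to compound 3 and a 3.7-fold lower number (0.57 log units; beyond the scatter) from compound 2 to compound 4, 1.3-fold (0.11 log units) apart, within the scatter of two such steps. This supports treating the change as transferable between these two cores, where it sits three bonds along the chain from an aromatic carbon in one pair and four in the other, but two pairs do not show that it would carry to any further core, give no separate reading of the one-bond shift in place, and offer no explanation for the lower numbers.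

The compounds shown leave open how the step would behave with a longer chain carrying the 1H-tetrazol-5-yl, or with an acylsulfonamide or a hydroxamic acid in its place. They also leave open whether the same step would appear on a core with an ethyl or a cyclohexyl group on the chain in place of the groups present here.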